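The compounds below may be only part of what the source reports. "The series", "measured", "known", "first", "only" and "open" are said of these compounds alone.

Measured so far in a functional assay on BSY-1 cells (Homo sapiens) for inhibition, read by sulforhodamine B assay, with a stated time of 48 h; a lower number here means a stronger inhibitor of growth, a higher number a weaker inhibitor of growth:
- compound 1 `CCCCCCCCCCCC[C@@H](O)[C@H]1CC[C@H]([C@H](O)CCCCCCCCCCN(C)C(=O)c2ccnn2C)O1`: 501 nM
- compound 2 `CCCCCCCCCCCC[C@@H](O)[C@H]1CC[C@H]([C@H](O)CCCCCCCCCCC(=O)Nc2ccnn2C)O1`: 95500 nM

Compound 2 is the higher of the two, at 95500 nM. Next in line is compound 3 `CCCCCCCCCCCC[C@@H](O)[C@H]1CC[C@H]([C@H](O)CCCCCCCCCCOC(=O)c2ccnn2C)O1`, which differs from compound 2 as follows: ((1-methyl-1H-pyrazol-5-yl)carbonyl)oxy in place of (1-methyl-1H-pyrazol-5-yl)carbamoyl on a saturated chain carbon, ten or more bonds along the chain from an oxygen on a saturated carbon and a saturated ring carbon. The change sits on a saturated chain carbon, at the end of the chain.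

For the measured compounds named here, only one measured step bears on this: a 190-fold higher number from compound 1 to compound 2 (2.28 log units; beyond the scatter). It is large and replaces methyl((1-methyl-1H-pyrazol-5-yl)carbonyl)amino with (1-methyl-1H-pyrazol-5-yl)carbamoyl. Compound 3 regains the (1-methyl-1H-pyrazol-5-yl)carbonyl unit of compound 1, which gives 501 nM. Going by the values given here, a large move to a lower number is therefore expected in this assay, though perhaps not the full distance, since no compound with this oxy group has been measured.

The expected change is a 64-fold lower number from compound 2 to compound 3 (1.80 log units; beyond the scatter). For compound 3 the estimate is 1500 nM, with an expected range of 250 nM to 15000 nM.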

Compound 3, concentration for 50% growth inhibition: 813 nM
Compound 3: middle estimate off by 1.8-fold (0.27 log units), on the high side; measured number inside the range.
By their numbers in this assay, from the lowest: compounds 1 and 3 (each within the scatter of the next); then compound 2.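

The a 120-fold lower number from compound 2 to compound 3 (2.07 log units; beyond the scatter) in this assay shows that this end of the chain tolerates a second linkage: ((1-methyl-1H-pyrazol-5-yl)carbonyl)oxy sits with methyl((1-methyl-1H-pyrazol-5-yl)carbonyl)amino, not with (1-methyl-1H-pyrazol-5-yl)carbamoyl. With a 1.6-fold higher number from compound 1 to compound 3 (0.21 log units; within the scatter), oxygen and methyl-bearing nitrogen cannot be told apart here, so among these three compounds the high number belongs to compound 2 alone, the only one without the (1-methyl-1H-pyrazol-5-yl)carbonyl unit. No supporting data bear on the reason for this result.

Compound 2 differs from the other two both in the amide hydrogen and in how the pyrazole is attached to the carbonyl, and these compounds do not separate the two. On these data alone, a ((1-methyl-1H-pyrazol-5-yl)carbonyl)amino group, which keeps the amide hydrogen on the chain side, would bear on that question, and the effect of a simple amine linkage remains open.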